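This account rests on a few compounds, and the source may have more. Where it says the series, first, only, none or still open, it means among the compounds named here.

Working notes on the series.

Within the data shown here, compound 1 `Nc1scc(-c2cccc(F)c2)c1C(=O)c1ccc(Cl)cc1` stands highest of the two numbers so far in a functional assay on CHO cells for agonist activity at adenosine receptor A1 (Homo sapiens), read by fluorescence and ERK phosphorylation, with stated times of 30 min and 1.5 h, tested at 3 uM (a higher number here means a stronger effect of the compound at the concentration tested, a lower number a weaker effect), where compound 1 gives 76%. Among the measured compounds shown here, the nearest comparator is compound 2 `Nc1scc(-c2ccc(I)cc2)c1C(=O)c1ccc(Cl)cc1`, which in this assay gives 54%; the one step available runs a number 22 percentage points lower from compound 1 to compound 2 (beyond the scatter), with 4-iodophenyl in place of 3-fluorophenyl on an aromatic carbon.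

The next compound, compound 3 `Nc1scc(-c2cccc([N+](=O)[O-])c2)c1C(=O)c1ccc(Cl)cc1`, is obtained from compound 1 by the change (nitro in place of fluoro on an aromatic carbon). The measured step bears on this only loosely: it exchanges the whole aryl group rather than one substituent kept in its place, so it shows that the pendant aryl ring is sensitive to change, but not the direction for a nitro substituent at this site. With that single, indirect precedent of modest size, a step of at most similar size downward, or none beyond the scatter, is expected in this assay.

Compound 3 is therefore estimated at 65%, with a range from 45% to 85%, the expected step being a number 11 percentage points lower from compound 1 to compound 3 (beyond the scatter).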

Compound 3, a percentage reported as activity, at one concentration (the size of the read-out at that concentration, not a potency): 53%
The estimate for compound 3 lay 12 percentage points above the measured number; low and high end bracket the measured number.
By their numbers in this assay, from the lowest: compounds 3 and 2 (each within the scatter of the next); then compound 1.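

In this assay the aryl ring stays and only its substituent changes, and the step is a number 23 percentage points lower from compound 1 to compound 3 (beyond the scatter); this shows that the place meta to a large group responds to the substituent alone, which the earlier exchange of the whole aryl group could not separate. Fluoro, with 1 heavy atom, gives way to nitro, with 3 heavy atoms and 2 hydrogen-bond acceptors, and the read-out falls without being lost, since compound 3 still gives 53% at the concentration tested. No measurement at hand accounts for this drop, so neither the larger size of the nitro group nor its added acceptors can be singled out.

The compounds shown leave open how an amine, a methoxy group or a carboxylic acid at this place would compare with fluoro and nitro, and so whether the read-out tracks any one feature of the substituent. Also open, going by these compounds, are how a plain phenyl ring without a substituent would read and whether nitro would give a similar step elsewhere on the ring.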